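Cyano for chloro on the aryl of compound 1

The compounds below may be only part of what the source reports. "The series", "measured", "known", "first", "only" and "open" are said of these compounds alone.

Compound 1 `C[C@H]1CC[C@@H]2[C@@H](OC(=O)[C@]23CC(c2ccc(Cl)cc2)=NO3)[C@]2(C)C(=O)C=C[C@@]12O` is the more lipophilic of the two measured compounds: in a physicochemical assay for lipophilicity (a lower number here means a more polar compound, a higher number a more lipophilic compound), compound 1 gives 2.09, while compound 2 `C[C@H]1CC[C@@H]2[C@@H](OC(=O)[C@]23CC(c2ccccc2F)=NO3)[C@]2(C)C(=O)C=C[C@@]12O` gives 1.58, a difference of a number 0.51 log units lower from compound 1 to compound 2 (beyond the scatter). Compound 3 `C[C@H]1CC[C@@H]2[C@@H](OC(=O)[C@]23CC(c2ccc(C#N)cc2)=NO3)[C@]2(C)C(=O)C=C[C@@]12O` differs from compound 1 by cyano in place of chloro on an aromatic carbon. For the measured compounds named here, no measured step matches this change; the only step available concerns a different aryl group, so the expectation rests on the change itself. Going by the values given here, a downward step is expected, a number 0.89 log units lower from compound 1 to compound 3 (beyond the scatter), larger than the one from compound 1 to compound 2. Compound 3 is therefore estimated at 1.2, within 0.6 to 1.7.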

Compound 3, partition coefficient: 1.17
Compound 3: middle estimate off by 0.03 log units, on the high side; measured number inside the range.
By their numbers in this assay, from the lowest: compound 3; then compound 2; then compound 1.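

Replacing chloro with cyano on this aromatic carbon, with nothing else changed, lowers the number in this assay (a number 0.92 log units lower from compound 1 to compound 3 (beyond the scatter)), a step beyond the scatter. The aryl group is thus shown to move this read-out by a change at this one carbon alone. The 4-cyanophenyl group also falls below the 2-fluorophenyl group (a number 0.41 log units lower from compound 2 to compound 3 (beyond the scatter)), which leaves compound 3 lowest of the three. Nothing available explains the size of these steps. On these data alone, whether an amine or a carboxylic acid at this position would fall lower than cyano remains open, as does whether cyano gives a similar step elsewhere on the aryl ring.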